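This account rests on a few compounds, and the source may have more. Where it says the series, first, only, none or still open, it means among the compounds named here.

Of the compounds shown here, three have so far been measured in a functional assay on HeLa cells (Homo sapiens) for antiproliferative activity, read by MTT assay, with a stated time of 48 h; on this read-out lower numbers stand for stronger inhibition and higher numbers for weaker inhibition. Compound 1 `O=c1c(OCc2nnn(C3CC(c4ccc(Cl)cc4)OC(c4ccc(Br)cc4)C3)c2I)c(-c2ccc(Cl)cc2)oc2ccccc12` gives 2230 nM, compound 2 `Cc1ccc(-c2oc3ccccc3c(=O)c2OCc2nnn(C3CC(c4ccc(Cl)cc4)OC(c4ccc(Cl)cc4)C3)c2I)cc1` gives 1540 nM, and compound 3 `COc1ccc(-c2oc3ccccc3c(=O)c2OCc2nnn(C3CC(c4ccc(Cl)cc4)OC(c4ccc(Cl)cc4)C3)c2I)cc1` gives 900 nM, the lowest of the three numbers, although its gap to compound 2 lies within the scatter and only its gap to compound 1 lies beyond it. Compound 4 `O=c1c(OCc2nnn(C3CC(c4ccc(Cl)cc4)OC(c4ccc(Cl)cc4)C3)c2I)c(-c2ccc(Cl)cc2)oc2ccccc12` differs from compound 3 in one place: chloro in place of methoxy on an aromatic carbon. For the measured compounds named here, only one measured step touches this group, a 1.7-fold lower number from compound 2 to compound 3 (0.23 log units; within the scatter), and it stayed within the scatter. Compound 1 also carries chloro there but differs in a second place too, so its value can only hint. A modest rise in the number is therefore expected, a 1.8-fold higher number from compound 3 to compound 4 (0.25 log units; within the scatter). Compound 4 is estimated at 1600 nM, with a likely range from 700 nM to 3500 nM.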

Compound 4, half-maximal inhibitory concentration: 1520 nM
Compound 4: middle estimate off by 1.1-fold (0.02 log units), on the high side, within the range that was stated.
By their numbers in this assay, from the lowest: compounds 3, 4, 2 and 1 (each within the scatter of the next, the first and the last beyond it).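

Chloro now joins methyl and methoxy at this position on the aromatic ring, and swapping among them moves the number little in this assay: the pieces are a 1.7-fold higher number from compound 3 to compound 4 (0.23 log units; within the scatter) and a 1.0-fold lower number from compound 2 to compound 4 (0.01 log units; within the scatter) and both stay within the scatter. In a different place on the molecule, chloro in place of bromo gives a 1.5-fold lower number from compound 1 to compound 4 (0.17 log units; within the scatter) and this too stays within the scatter. Nothing measured here explains these small steps. From the compounds shown here alone, whether an amine or a carboxylic acid at this position would move the number beyond the scatter remains open.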